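The source may hold more compounds than are shown below. What is called first, only, known or untested is meant among the compounds shown, and "the series" means these compounds.

In an ADME assay on L02 cells (Homo sapiens) for cytotoxicity, read by MTT assay, with a stated time of 24 h (a lower number here means a stronger inhibitor, a higher number a weaker inhibitor), compound 1 `O=C1/C(=C/c2ccccc2F)CN(S(=O)(=O)c2ccc(F)cc2)C/C1=C\c1ccccc1F` gives 19100 nM and compound 2 `CC(=O)Nc1ccc(S(=O)(=O)N2C/C(=C\c3ccccc3F)C(=O)/C(=C/c3ccccc3F)C2)cc1` gives 11600 nM. Going by the values given here, these are the only two numbers available and they lie within the scatter of each other, so neither can be ranked against the other. Compound 3 `N#Cc1ccc(/C=C2\CN(S(=O)(=O)c3ccc(F)cc3)C/C(=C\c3ccccc3F)C2=O)cc1` has not yet been measured. It departs from compound 1 in one place: 4-cyanophenyl in place of 2-fluorophenyl on a double-bonded chain carbon bound to a double-bonded ring carbon. Among the compounds with values here, no measured compound carries the 4-cyanophenyl group, and both measured compounds keep the 2-fluorophenyl groups, so the data give no direct reading of this change. Within the data shown here, the one measured step, a 1.6-fold lower number from compound 1 to compound 2 (0.22 log units; within the scatter), is acetamido in place of fluoro on an aromatic carbon, a change at another place. Among the measured compounds shown here, it is the sole guide, so a step no larger than the scatter is expected in this assay, with no firm direction. The estimated step is a 1.3-fold lower number from compound 1 to compound 3 (0.10 log units; within the scatter), a small move that is expected to be hard to tell from noise. In this assay the estimate for compound 3 is 15000 nM, with an expected range of 7000 nM to 32000 nM.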

Compound 3, half-maximal inhibitory concentration: 21900 nM
The estimate for compound 3 lay 1.5-fold (0.16 log units) below the measured number; the measured number falls inside the stated range.
By their numbers in this assay, from the lowest: compounds 2, 1 and 3 (each within the scatter of the next).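

In this assay this position can now be read directly, and the reading is a 1.1-fold higher number from compound 1 to compound 3 (0.06 log units; within the scatter) for 4-cyanophenyl in place of 2-fluorophenyl on a double-bonded chain carbon bound to a double-bonded ring carbon. Going by these compounds alone, compound 1 and compound 3 therefore cannot be told apart in this assay: this one exchange, which removes a fluorine and brings in a nitrile, produces no step beyond the scatter, so the earlier finding that the acetamido-for-fluoro change elsewhere gives no resolved step now has a counterpart at a second place. No measurement is available that bears on why this exchange leaves the number within the scatter.

This single exchange of one substituted phenyl for another leaves open whether the place would respond differently to a phenyl carrying an amine or a carboxylic acid, or to a longer chain in place of the ring. It also leaves open whether 4-cyanophenyl at this place would give a similar reading on the acetamido-bearing compound 2, or with both 2-fluorophenyl groups exchanged.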